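This account rests on a few compounds, and the source may have more. Where it says the series, first, only, none or still open, it means among the compounds named here.

Values so far in a functional assay on JeKo-1 cells (Homo sapiens) for antiproliferative activity (on this read-out higher numbers stand for weaker inhibition and lower numbers for stronger inhibition), by compound

- Compound 1 (`Nc1ncnc2c1c(-c1ccc(NC(=O)c3ccccc3)cc1)cn2[C@H]1CCN(C[C@@H]2CO2)C1`) gives 5390 nM
- Compound 2 (`Nc1ncnc2c1c(-c1ccc(Oc3ccccc3)cc1)cn2C[C@H]1CCCN1C[C@@H](O)CO`) gives 9540 nM
- Compound 3 (`CC(C)(C)c1ccc(C(=O)Nc2cccc(-c3cn([C@H]4CCN(C[C@@H]5CO5)C4)c4ncnc(N)c34)c2)cc1`) gives 2540 nM

Compound 1 sits level with compound 2 within the scatter, at the upper end of these three numbers, while compound 3 shows a lower number than compound 1, a gap that lies beyond the scatter.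

The next compound, compound 4 (`CC(C)(C)c1ccc(Oc2ccc(-c3cn([C@H]4CCN(C[C@@H]5CO5)C4)c4ncnc(N)c34)cc2)cc1`), has not yet been measured. It keeps the core of compound 1 and differs from it in one place (4-(tert-butyl)phenoxy in place of benzamido on an aromatic carbon), with 4-(tert-butyl)phenoxy in place of benzamido on an aromatic carbon, para to a large group.

Within the data shown here, no measured pair shows this swap directly, so the evidence is indirect. Compound 3, which also carries a tert-butyl group, gives (2540 nM), and compound 2, which carries a phenoxy group but differs elsewhere too, gives (9540 nM). In this assay a small move toward lower numbers is therefore expected, not clearly beyond the scatter. The estimated step is (a 1.8-fold lower number from compound 1 to compound 4 (0.25 log units; within the scatter)) and it remains uncertain. For compound 4 the expected value is 3000 nM (estimated range 900 nM to 9000 nM).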

Compound 4, half-maximal inhibitory concentration: 14800 nM
Compound 4: middle estimate off by 4.9-fold (0.69 log units), on the low side; the measured number lies above the stated range.
By their numbers in this assay, from the lowest: compound 3; then compounds 1, 2 and 4 (each within the scatter of the next, the first and the last beyond it).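

In this assay, among these compounds, the swap at this aromatic carbon, para to a large group, gives the first direct reading of a change at this position: 4-(tert-butyl)phenoxy in place of benzamido comes with a 2.7-fold higher number from compound 1 to compound 4 (0.44 log units; beyond the scatter). On the core of compound 1, benzamido therefore gives the stronger inhibition of the two groups, and this larger group, with its tert-butyl, does not improve on it. The swap also replaces a group with 1 hydrogen-bond donor by one with 0 hydrogen-bond donors, but this single pair cannot separate that difference from the others between the two groups, and no measurement is available that would explain the step.

The compounds shown leave open whether the step follows from the exchange of the amide link for the ether oxygen or from the tert-butyl group, as no pair here varies one of these alone. On these data alone, how a morpholine or a carboxylic acid would read in place of benzamido at this carbon also remains open.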